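The source may hold more compounds than are shown below. What is called first, only, known or untested is meant among the compounds shown, and "the series" means these compounds.

Measured compounds in an ADME assay on MT4 cells (Homo sapiens) for cytotoxicity, read by MTT assay, with a stated time of 5 days; on this read-out higher numbers stand for lower toxicity in this test and lower numbers for higher toxicity in this test:
compound 1, `N#Cc1cccc(CN2C(=O)N(Cc3ccccc3)S(=O)(=O)n3cccc32)c1`: > 318000 nM
compound 2, `O=C1N(Cc2ccccc2Cl)c2cccn2S(=O)(=O)N1Cc1cccc(F)c1`: 231000 nM
compound 3, `N#CCN1C(=O)N(Cc2cccc(F)c2)S(=O)(=O)n2cccc21`: 172000 nM

Compound 1 stands only at a limit in this assay; its reading is the limit of > 318000 nM in this assay, at which 1 of the 3 values shown sits, and not a number. Compound 2 gives a number, and compound 3 gives a number within the scatter of it.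

Compound 4, `O=C1N(Cc2ccc(F)cc2)c2cccn2S(=O)(=O)N1Cc1ccccc1`, differs from compound 1 by 4-fluorophenyl in place of 3-cyanophenyl on a saturated chain carbon bound to an amide-type nitrogen in a ring. Among the measured compounds shown here, the only measured step at the same place is a 1.3-fold lower number from compound 2 to compound 3 (0.13 log units; within the scatter), and that change is within the scatter. For the measured compounds named here, no measured step exchanges one aryl group for another at that place, so the bearing of that step on compound 4 is indirect. All three readings sit at or near the top of the range this assay reports. A step no larger than the scatter is therefore expected from compound 1 to compound 4, an at least 1.1-fold lower number from compound 1 to compound 4 (0.07 log units; that floor lies within the scatter), with a fair chance that compound 4 is again reported only as a limit. The estimate for compound 4 is 270000 nM, in a range from 140000 nM to 400000 nM.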

Compound 4, half-maximal cytotoxic concentration: 150000 nM
Estimate against measurement, compound 4: 1.8-fold (0.26 log units) above; measured number inside the range.
By their numbers in this assay, from the lowest: compounds 4, 3 and 2 (each within the scatter of the next). At a limit, above all of these: compound 1.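

In this assay, among the compounds shown here, replacing 3-cyanobenzyl with 4-fluorobenzyl gives the only step at this place that lies beyond the scatter: an at least 2.1-fold lower number from compound 1 to compound 4 (0.32 log units; beyond the scatter). For the compounds shown here, an exchange of one aryl group for another on this saturated chain carbon can therefore move the reading, whereas the only earlier step here, a 1.3-fold lower number from compound 2 to compound 3 (0.13 log units; within the scatter), did not separate its two compounds. The reading for compound 1 is a limit and not a number, so the size of this step is only a floor: the limit of > 318000 nM in this assay, at which 1 of the 4 values shown sits.

The loss of the nitrile and the entry of the fluorine occur together in this single pair, so their shares in the step cannot be separated. Still open, going by these compounds, is how the reading would respond to a carboxylic acid or an aminomethyl group on the phenyl ring at this place.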